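This account rests on a few compounds, and the source may have more. Where it says the series, first, only, none or still open, it means among the compounds named here.

For the measured compounds named here, in an ADME assay on BHK-21 cells (Mesocricetus auratus) for cytotoxicity, read by MTT assay, with a stated time of 96 h (on this read-out lower numbers stand for higher toxicity in this test and higher numbers for lower toxicity in this test), compound 1 `Fc1ccc(F)c(/N=N/c2ccc(NC[C@@H]3CCCN4CCCC[C@H]34)c3c2CCCC3)c1` gives 38000 nM, the only actual number so far. Compound 2 `Fc1ccc(F)c(/N=N/Nc2ccccc2)c1` is reported only as a limit, > 100000 nM. Compound 3 `CN(/N=N/c1cccc([N+](=O)[O-])c1)c1ccccc1` is likewise reported only as a limit, > 100000 nM. Compound 4 `Fc1ccc(/N=N/c2ccc(NC[C@@H]3CCCN4CCCC[C@H]34)c3c2CCCC3)c(F)c1` keeps the core of compound 1 and differs at one place: 2,4-difluorophenyl in place of 2,5-difluorophenyl on a double-bonded nitrogen, with 2,4-difluorophenyl in place of 2,5-difluorophenyl on a double-bonded nitrogen. Going by the values given here, no measured pair gives a step to go by, so nothing beyond the scatter is expected, in either direction. The expected step of no change at the digits printed from compound 1 to compound 4 (within the scatter) is therefore an estimate of no real change. Compound 4 is estimated at 38000 nM, with an expected range of 16000 nM to 85000 nM.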

Compound 4, half-maximal cytotoxic concentration: 9000 nM
Compound 4: middle estimate off by 4.2-fold (0.63 log units), on the high side; measured number outside the range, below it.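

In this assay, 2,4-difluorophenyl in place of 2,5-difluorophenyl on a double-bonded nitrogen gives a 4.2-fold lower number from compound 1 to compound 4 (0.63 log units; beyond the scatter) with no atom gained or lost, the lower number standing for higher toxicity in this test. This place on the core of compound 1 therefore responds to a rearrangement of the same atoms alone. No measurement shown accounts for the step.

On these data alone, whether a chlorophenyl or a pyridyl ring at this place would take the number lower or back up remains open. As far as these compounds go, whether the same exchange gives a similar step on another core also remains open.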